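The source may hold more compounds than are shown below. What is called first, only, known or untested is meant among the compounds shown, and "the series" means these compounds.

Compound 1 `O=C1O[C@@H](CO)CN1c1ccc(-n2cc(-c3ccccn3)cn2)c(F)c1` carries a hydroxy group on a saturated chain carbon bound to a saturated ring carbon. In an ADME assay on HEK293-A cells (Homo sapiens) for cytotoxicity, read by MTT assay, with a stated time of 48 h (on this read-out lower numbers stand for stronger inhibition and higher numbers for weaker inhibition), compound 1 gives only a limit, > 400 ug/mL. Among the compounds with values here, compound 2 `CCN1CCN(C[C@H]2CN(c3ccc(-n4cc(-c5ccccn5)cn4)c(F)c3)C(=O)O2)CC1` puts 4-ethylpiperazin-1-yl at that carbon, and in this assay compound 2 gives 99 ug/mL; the one measured step, an at least 4.0-fold lower number from compound 1 to compound 2 (0.60 log units; beyond the scatter), is bounded in size by the limit of > 400 ug/mL in this assay, at which 1 of the 2 values shown sits. Compound 3 `CCNC(=O)NC[C@H]1CN(c2ccc(-n3cc(-c4ccccn4)cn3)c(F)c2)C(=O)O1` differs from compound 1 by (ethylcarbamoyl)amino in place of hydroxy on a saturated chain carbon bound to a saturated ring carbon. Within the data shown here, no measured step matches this change, so the expectation leans on compound 1 alone. For compound 3 the estimated value in this assay is 350 ug/mL, between 120 ug/mL and 800 ug/mL. This is an expected step of an at least 1.1-fold lower number from compound 1 to compound 3 (0.05 log units; that floor lies within the scatter), with a fair chance of again ending at the limit.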

Compound 3, half-maximal inhibitory concentration: 29 ug/mL
For compound 3 the middle estimate is 12-fold (1.08 log units) above the measured one; measured number outside the range, below it.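

In this assay, replacing hydroxy at this saturated chain carbon gives a lower number with a second group, not only with 4-ethylpiperazin-1-yl: (ethylcarbamoyl)amino gives an at least 13-fold lower number from compound 1 to compound 3 (1.13 log units; beyond the scatter) at this carbon. The two replacements also separate from each other, with a 3.4-fold lower number from compound 2 to compound 3 (0.53 log units; beyond the scatter) on the same core. The size of the step from the hydroxy compound remains bounded by a limit of the assay: the limit of > 400 ug/mL in this assay, at which 1 of the 3 values shown sits.

Open, going by these compounds, is how a primary amine or a carboxylic acid at this carbon would read, and whether a longer chain in place of the ethyl of (ethylcarbamoyl)amino would shift the number further.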